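The source may report more compounds than this note shows. Statements on the series, on what has been measured and on what is new or still open speak of the compounds shown alone.

Compound 1 `COc1ccc(-c2nc3cc(/C(C)=N/NC(N)=S)ccc3[nH]2)c(OC)c1`: > 100000 nM (a limit)
Compound 2 `COc1ccc(-c2nc3cc(/C(C)=N/NC(N)=O)ccc3n2C2CCCCC2)c(OC)c1`: 36000 nM
Compound 3 `C/C(=N\NC(N)=S)c1ccc2c(c1)nc(-c1ccc(Cl)cc1)n2C1CCCCC1`: > 100000 nM (a limit)

These results come from an ADME assay on MDBK cells (Bos taurus) for cytotoxicity, read by MTT assay, with a stated time of 96 h; a lower number here means that less compound is tolerated, a higher number that more compound is tolerated. Compound 3 stands at > 100000 nM, which is a limit of the assay and not a number. Compound 1 likewise gives only a limit, > 100000 nM. The data therefore cluster at the limit of > 100000 nM in this assay, at which 2 of the 3 values shown sit. Compound 2 alone has a true number, 36000 nM.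

Compound 4 `COc1ccc(-c2nc3cc(/C(C)=N/NC(N)=S)ccc3n2C2CCCCC2)c(OC)c1` differs from compound 3 by one swap: 2,4-dimethoxyphenyl in place of 4-chlorophenyl on an aromatic carbon. The 2,4-dimethoxyphenyl takes the place of 4-chlorophenyl on an aromatic carbon, next to the ring atom that bears a cyclohexyl group.

Within the data shown here, no measured step shows what such a swap does, so only a modest shift is expected, toward less compound tolerated if anything. That direction is allowed for since compound 2 gives 36000 nM, showing that true numbers do occur in this assay. The estimated change is an at least 1.4-fold lower number from compound 3 to compound 4 (0.15 log units; that floor lies within the scatter). For compound 4 the estimated value is 70000 nM, with an expected range from 25000 nM to 130000 nM.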

Compound 4, half-maximal cytotoxic concentration: > 100000 nM
Compound 4: a limit, no number; the forecaster's own chance of this, stated with the estimate: 50%; middle value at least 1.4-fold (0.15 log units) from the limit.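

In this assay, among these compounds, compound 4 gives the first step between measured compounds that can be read: with a sulfur-bearing group in place of an oxygen-bearing group on an amine nitrogen, there is an at least 2.7-fold higher number from compound 2 to compound 4 (0.44 log units; beyond the scatter). The steps to compound 4 from compound 3 and from compound 1 cannot be read, as each of these compounds gives only a limit. With the sulfur-bearing group kept, neither 2,4-dimethoxyphenyl in place of 4-chlorophenyl nor cyclohexyl in place of hydrogen brings a true number, and the values stay grouped at one end: the limit of > 100000 nM in this assay, at which 3 of the 4 values shown sit.

Going by these compounds, the true numbers behind the limits of compound 1, compound 3 and compound 4 stay open, and so does the size of both swaps. Also open, on these data alone, is what an amine or a carboxylic acid on the phenyl ring, or a longer chain in place of cyclohexyl, would give.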